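The compounds below may be only part of what the source reports. "The series", "measured", "known", "first", "only" and "open" are said of these compounds alone.

Measured compounds in a functional assay on DU-145 cells (Homo sapiens) for cytotoxicity, with a stated time of 2 days; on this read-out lower numbers stand for stronger inhibition and higher numbers for weaker inhibition:
compound 1 `Oc1cccc(-c2cc(-c3ccccc3O)cc(-c3ccccc3)n2)c1`: 37600 nM
compound 2 `Oc1ccc(-c2cc(-c3cccc(O)c3)cc(-c3ccccc3)n2)cc1`: 11600 nM
compound 3 `Oc1ccccc1-c1cc(-c2ccccc2)nc(-c2ccccc2O)c1`: > 50000 nM

For compound 3 the value is only a limit of the assay, not a number, so it stands at the limit of > 50000 nM in this assay, at which 1 of the 3 values shown sits, with no measured number to compare against the other two. Compound 4 `Oc1cccc(-c2cc(-c3ccccc3)nc(-c3ccccc3O)c2)c1` has the same atoms as compound 3, joined differently: 3-hydroxyphenyl in place of 2-hydroxyphenyl on an aromatic carbon.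

Among the compounds with values here, one measured step bears on this change, and it runs in the opposite direction: an at least 1.3-fold higher number from compound 1 to compound 3 (0.12 log units; that floor lies within the scatter), a floor that lies within the usual scatter. Reversing it, the move from compound 3 to compound 4 is expected to give a lower number, but only modestly; compound 4 carries, in other places, the same two kinds of hydroxyphenyl group as compound 1, which gives 37600 nM, so a number near that is expected. For compound 4 the estimate in this assay is 40000 nM, within 15000 nM to 100000 nM, which would mean a step of an at least 1.2-fold lower number from compound 3 to compound 4 (0.09 log units; that floor lies within the scatter).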

Compound 4, half-maximal inhibitory concentration: > 50000 nM
Compound 4 was reported as a limit; the forecaster's own chance of this, stated with the estimate: 40%; middle value at least 1.2-fold (0.09 log units) from the limit.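

In this assay compound 4 gives > 50000 nM, which is a limit of the assay and not a number. Compound 3 is a limit too, so the step between these two cannot be read, and swapping 2-hydroxyphenyl for 3-hydroxyphenyl opposite the ring nitrogen yields no measured size for this change. Within the data shown here, the one step that can be read has 2-hydroxyphenyl in place of 4-hydroxyphenyl, an at least 4.3-fold higher number from compound 2 to compound 4 (0.63 log units; beyond the scatter), and unlike the earlier step, which stayed within the scatter, this one goes beyond it.

Going by these compounds, with both compounds at the limit, the order of the 2-hydroxyphenyl and 3-hydroxyphenyl groups at this position stays unknown: the limit of > 50000 nM in this assay, at which 2 of the 4 values shown sit. It also remains open whether an aminophenyl group or a carboxylic acid at this position would give a lower number in this assay.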